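Replacing 4-hydroxyphenyl: from compound 3 to compound 4

The source may report more compounds than this note shows. Statements on the series, on what has been measured and on what is new or still open speak of the compounds shown alone.

Measured in a functional assay on A549 cells (Homo sapiens) for inhibition, read by sulforhodamine B assay; on this read-out lower numbers stand for stronger inhibition of growth and higher numbers for weaker inhibition of growth:
- compound 1 `Oc1cccc2[nH]c(-c3ccc(-c4ccc(-c5ccc(C(F)(F)F)cc5)cc4)cc3)nc12`: 3610 nM
- compound 2 `Oc1cccc2[nH]c(-c3ccc(-c4ccc(-c5ccc(OC(F)(F)F)cc5)cc4)cc3)nc12`: 190 nM
- compound 3 `Oc1ccc(-c2ccc(-c3ccc(-c4nc5c(O)cccc5[nH]4)cc3)cc2)cc1`: 170 nM

Compound 3 sits at the low end of these numbers, but it cannot be separated from its nearest neighbour: a 1.1-fold lower number from compound 2 to compound 3 (0.05 log units; within the scatter). The distance to the high end is large: a 21-fold lower number from compound 1 to compound 3 (1.33 log units; beyond the scatter).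

The next structure is compound 4 `Oc1cccc2[nH]c(-c3ccc(-c4ccc(-c5cccc(Cl)c5)cc4)cc3)nc12`, not yet measured in this assay. The change is 3-chlorophenyl in place of 4-hydroxyphenyl on an aromatic carbon.

Two measured steps show that changes on this outer ring can move the number a long way: a 19-fold lower number from compound 1 to compound 2 (1.28 log units; beyond the scatter) and a 21-fold lower number from compound 1 to compound 3 (1.33 log units; beyond the scatter). Going by the values given here, neither involves chlorine, and no measured compound carries a substituent in the position found in compound 4, so the comparison is loose. Of the three measured compounds, only compound 1 has no oxygen on this ring, and compound 1 gives 3610 nM. Compound 4 also lacks oxygen there, so a move towards weaker inhibition is expected, probably not the whole distance. The expected step is a 3.5-fold higher number from compound 3 to compound 4 (0.55 log units; beyond the scatter). For compound 4 the estimated value is 600 nM, with an expected range of 150 nM to 3000 nM.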

Compound 4, concentration for 50% growth inhibition: 2400 nM
Compound 4: the middle estimate sits 4.0-fold (0.60 log units) below what was measured; the range from low to high includes it.
By their numbers in this assay, from the lowest: compounds 3 and 2 (each within the scatter of the next); then compounds 4 and 1 (each within the scatter of the next).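

In this assay, 3-chlorophenyl on the outer ring gives a large step away from both oxygen-bearing compounds: a 14-fold higher number from compound 3 to compound 4 (1.15 log units; beyond the scatter) and a 13-fold higher number from compound 2 to compound 4 (1.10 log units; beyond the scatter). Against the other compound with no oxygen on this ring, the step is small, a 1.5-fold lower number from compound 1 to compound 4 (0.18 log units; within the scatter), so 3-chlorophenyl and 4-(trifluoromethyl)phenyl cannot be told apart here, and the four compounds fall into two groups with no exception: 4-hydroxyphenyl and 4-(trifluoromethoxy)phenyl at the low numbers, 3-chlorophenyl and 4-(trifluoromethyl)phenyl at the high numbers. No supporting data bear on why the compounds divide in this way.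

Compound 4 differs from compound 3 in both the substituent and its place on the ring, so the compounds shown cannot separate these two changes; 4-chlorophenyl would give a direct comparison with compound 1, compound 2 and compound 3. Going by these compounds, it also remains open whether the low numbers depend on oxygen as such or would extend to other groups on this ring, such as 4-aminophenyl, 4-methoxyphenyl or 3-hydroxyphenyl.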